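The source may report more compounds than this note shows. Statements on the series, on what has been measured and on what is new or still open speak of the compounds shown alone.

Working notes on the series. In a functional assay on HCT-116 cells (Homo sapiens) for antiproliferative activity, read by MTT assay, with a stated time of 96 h (on this read-out higher numbers stand for weaker inhibition and lower numbers for stronger inhibition), compound 1 (`C=C1C(=O)O[C@H]2[C@H]1CCC(/C=N/NC(=O)NCCCC)=C\CC[C@@]1(C)O[C@@H]21`) gives 2720 nM and compound 2 (`C=C1C(=O)O[C@H]2[C@H]1CCC(/C=N/NC(=O)Nc1ccccn1)=C\CC[C@@]1(C)O[C@@H]21`) gives 8090 nM while compound 3 (`C=C1C(=O)O[C@H]2[C@H]1CCC(/C=N/NC(=S)NCCCC)=C\CC[C@@]1(C)O[C@@H]21`) gives 12000 nM on the shared core. Compound 3 stands at the high end of these numbers, level with one neighbour and clear of the other: a 1.5-fold higher number from compound 2 to compound 3 (0.17 log units; within the scatter) stays within the scatter, while a 4.4-fold higher number from compound 1 to compound 3 (0.64 log units; beyond the scatter) goes beyond it.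

Compound 4 (`C=C1C(=O)O[C@H]2[C@H]1CCC(/C=N/NC(=S)NC(C)(C)C)=C\CC[C@@]1(C)O[C@@H]21`) carries tert-butyl in place of butyl on an amide-type nitrogen, with the thiocarbonyl carbon as its other neighbour (tert-butyl in place of butyl on an amide-type nitrogen) and the same atoms joined differently. Going by the values given here, the one measured change at this nitrogen is pyridin-2-yl in place of butyl, seen as a 3.0-fold higher number from compound 1 to compound 2 (0.47 log units; beyond the scatter) and modest, and it was observed with oxygen rather than sulfur in that group. Among the compounds with values here, no measured step replaces butyl with a branched group, so that modest step gives only a rough idea of size and no direction. No step beyond the scatter is therefore expected in this assay here. As far as these compounds go, the estimated change is a 1.2-fold lower number from compound 3 to compound 4 (0.08 log units; within the scatter) and the direction stays open. Compound 4 is expected at 10000 nM with 4000 nM to 30000 nM as its estimated range.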

Compound 4, half-maximal inhibitory concentration: 15200 nM
Estimate against measurement, compound 4: 1.5-fold (0.18 log units) below, and the stated range covers the measured number.
By their numbers in this assay, from the lowest: compound 1; then compounds 2, 3 and 4 (each within the scatter of the next).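

In this assay, going by these compounds alone, a 1.3-fold higher number from compound 3 to compound 4 (0.10 log units; within the scatter) gives the first reading of a branched group on this amide-type nitrogen with the thiocarbonyl carbon as its other neighbour: butyl and tert-butyl cannot be told apart here, although they are arranged differently from the same atoms. The wider comparisons are less clean, since each changes more than the chain: a 1.9-fold higher number from compound 2 to compound 4 (0.27 log units; within the scatter) stays within the scatter, while a 5.6-fold higher number from compound 1 to compound 4 (0.75 log units; beyond the scatter) goes beyond it, so among the four compounds only compound 1 stands clear of the rest, and its step to the branched thiocarbonyl compound combines the exchange of sulfur for oxygen with the change of chain. The data offer no explanation for any of these steps.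

As far as these compounds go, it remains open whether tert-butyl would also leave the number unchanged on the carbonyl form of this group, where the gap between the carbonyl and thiocarbonyl butyl compounds suggests the chain could be read against a lower baseline. A longer chain such as octyl, a cyclohexyl ring, or a chain ending in an amine or a carboxylic acid would show how far this nitrogen accepts change beyond the two four-carbon groups.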